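Swapping ethyl for methoxy at the assay limit

The compounds below may be only part of what the source reports. "The series", "measured", "known", "first", "only" and "open" are said of these compounds alone.

Compound 1 `CCN1CCN(c2ccc(S(=O)(=O)Oc3ccccc3OC)cc2)C1=O`: > 100000 nM
Compound 2 `CCCN1CCN(c2ccc(S(=O)(=O)Oc3ccccc3C)cc2)C1=O`: > 100000 nM
Compound 3 `CCCN1CCN(c2ccc(S(=O)(=O)Oc3ccccc3CC)cc2)C1=O`: > 100000 nM

In a functional assay on HT-29 cells (Homo sapiens) for antiproliferative activity, read by sulforhodamine B assay, with a stated time of 48 h (a lower number here means a stronger inhibitor, a higher number a weaker inhibitor), compound 3 gives > 100000 nM as its result, which is a limit and not a number. It shares the limit of > 100000 nM in this assay, at which 3 of the 3 values shown sit, with compound 1 and compound 2, so the data do not separate the three. Compound 4 `CCCN1CCN(c2ccc(S(=O)(=O)Oc3ccccc3OC)cc2)C1=O` has methoxy in place of ethyl on an aromatic carbon when set against compound 3. Among the measured compounds shown here, the only measured step, a step that the two limits leave unreadable from compound 2 to compound 3, offers no size to carry over. Compound 1 carries the same 2-methoxyphenyl group and gives > 100000 nM as a limit too. The expected change, a number no higher from compound 3 to compound 4 (the limit leaves the size open), is therefore none beyond the scatter, in no particular direction. Compound 4 is estimated at 100000 nM in this assay, with an expected range from 30000 nM to 200000 nM and most likely only a limit reported.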

Compound 4, half-maximal inhibitory concentration: > 100000 nM
Compound 4 ended at the assay's limit; the forecaster's own chance of this, stated with the estimate: 90%; the middle value lies on the limit itself.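

Compound 4 stops at the same limit as compound 1, compound 2 and compound 3, so no step among them can be read: the limit of > 100000 nM in this assay, at which 4 of the 4 values shown sit.

As far as these compounds go, whether methoxy, ethyl or methyl on the aromatic ring makes any difference to antiproliferative activity stays open.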